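Guanylhydrazone series: dichlorothiophene swap on the fused core

The source may report more compounds than this note shows. Statements on the series, on what has been measured and on what is new or still open speak of the compounds shown alone.

Going by the values given here, compound 1 `N=C(N)N/N=C/c1c(-c2cccs2)nc2n1CCS2` is the weakest of the three compounds measured so far. In a functional assay on cells (Cancer cell lines, Homo sapiens) for inhibition (on this read-out lower numbers stand for stronger inhibition of growth and higher numbers for weaker inhibition of growth), compound 1 gives 39800 nM, the highest of the three numbers. Compound 3 `Cc1cn2c(/C=N/NC(=N)N)c(-c3ccsc3)nc2s1`, which also carries the guanylhydrazone arm but on a different core, gives 11000 nM in this assay, a lower number than compound 1 by a margin beyond the scatter. Compound 2 `Cc1cn2c(/C=N/Nc3ccccn3)c(-c3ccc(Cl)c([N+](=O)[O-])c3)nc2s1` gives 9120 nM, the lowest of the three and likewise beyond the scatter from compound 1. Neither of these differs from compound 1 in one place only, so no single-step comparison can be drawn from the measured compounds.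

Compound 4 `N=C(N)N/N=C/c1c(-c2cc(Cl)sc2Cl)nc2n1CCS2` is the next compound to be tested. It differs from compound 1 as follows: 2,5-dichlorothiophen-3-yl in place of thiophen-2-yl on an aromatic carbon. No measured pair mirrors this change, so the direction rests only on the three numbers shown. A modest improvement is expected, with the step from compound 1 to compound 4 estimated at a 2.7-fold lower number from compound 1 to compound 4 (0.42 log units; beyond the scatter). For compound 4 the expected value in this assay is 15000 nM, within a range from 4000 nM to 60000 nM.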

Compound 4, concentration for 50% growth inhibition: 10500 nM
Beside the measured number, compound 4's estimate is 1.4-fold (0.15 log units) above it; the measured number falls inside the stated range.
By their numbers in this assay, from the lowest: compounds 2, 4 and 3 (each within the scatter of the next); then compound 1.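

In this assay, going by these compounds alone, 2,5-dichlorothiophen-3-yl in place of thiophen-2-yl gives a 3.8-fold lower number from compound 1 to compound 4 (0.58 log units; beyond the scatter) and provides the first single-place comparison. The aromatic carbon next to the ring nitrogen therefore accepts this chlorinated thiophene on the shared core with the guanylhydrazone arm unchanged, and growth inhibition is stronger than with thiophen-2-yl. The swap changes both the thiophene attachment point and the chlorine substitution, so this one step cannot assign the gain to either change.

On these data alone, whether both chlorines are needed remains open, as does whether a single chlorine on the thiophene, a cyclohexyl ring or a primary amine at this carbon would give a similar result. Nothing available on the compounds offers an explanation for the step.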